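The source may report more compounds than this note shows. Statements on the series, on what has been measured and on what is new or still open speak of the compounds shown alone.

Measured so far:
- Compound 1, `Cc1ccc(Nc2nccc(-c3ccnc4ccccc34)n2)cc1` — in a functional assay on U-251 cells (Homo sapiens) for cytotoxicity, read by sulforhodamine B assay, with a stated time of 48 h, tested at 50 uM (on this read-out lower numbers stand for less inhibition and higher numbers for more inhibition at the one concentration tested (going by the name of the read-out)), compound 1 gives 100%
- Compound 2, `FC(F)(F)c1ccc(Nc2nccc(-c3cnc4ccccc4c3)n2)cc1` — in this assay compound 2 gives 49.8%

Compound 1 stands at the top of these two numbers. Among the measured compounds shown here, the only other measured compound, compound 2, reads far lower, and that gap is well beyond the scatter of repeated measurements of this kind. Compound 2 also carries a different arrangement of its outer rings, so the two differ in more than one place and no single change can be tied to the gap between them.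

Compound 3, `Nc1nccc(-c2ccnc3ccccc23)n1`, has not yet been measured in this assay. Its difference from compound 1 is a small one on paper: hydrogen in place of 4-methylphenyl on a nitrogen on an aromatic ring. The whole 4-methylphenyl group is taken away and only a hydrogen remains on that ring nitrogen.

For the measured compounds named here, with no measured pair showing this exact change, the expectation rests on compound 1 alone. Removing a group of seven heavy atoms is expected to cost activity, so a step down in this assay beyond the scatter is expected, of about a number 60 percentage points lower from compound 1 to compound 3 (beyond the scatter). Compound 3 is therefore estimated to give about 40% in this assay, within a range from 10% to 75%.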

Compound 3, a percentage reported as inhibition, at one concentration (the size of the read-out at that concentration, not a potency): 100%
The estimate for compound 3 lay 60 percentage points below the measured number, outside the stated range (above it).
By their numbers in this assay, from the lowest: compound 2; then compounds 1 and 3 (each within the scatter of the next).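

Replacing 4-methylphenyl with hydrogen on a nitrogen on an aromatic ring gives no change at the digits printed from compound 1 to compound 3 (within the scatter) in this assay and so shows something compound 1 alone could not: at this one concentration, the read-out does not depend on the 4-methylphenyl group, and the simple amino form of compound 3 keeps all of it. Among the compounds shown here, the read-out is the size of the effect at a single concentration, so this result shows only that the two compounds cannot be told apart at that concentration, and it says nothing about the size of their effects at any other concentration. No measurement shown here offers an explanation for this result.

Still open, as far as these compounds go, is whether the two compounds would separate at lower concentrations, and whether other groups on this nitrogen, such as a small methyl, an acetyl, a longer butyl chain or a phenyl ring carrying a carboxylic acid, would also leave the read-out in the same place. Compound 2 differs from compound 1 and compound 3 in more than one place, so it cannot show what its trifluoromethyl group or its different outer ring arrangement contributes on its own.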